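The source may report more compounds than this note shows. Statements on the series, on what has been measured and on what is new or still open speak of the compounds shown alone.

Measured compounds: compound 1 `COc1cc(/C=C/c2ccc(OC)cc2O)cc(OC)c1` with 8400 nM and compound 2 `COc1ccc(/C=C/c2cccc(OC)c2O)c(OC)c1` with 5100 nM in a functional assay on MDA-MB-468 cells (Homo sapiens) for antiproliferative activity, read by MTT assay; a lower number here means a stronger inhibitor, a higher number a weaker inhibitor.

Compound 1 shows the highest of the two numbers, but its gap to compound 2 lies within the scatter, so the two are treated as alike. Compound 3 `COc1ccc(/C=C/c2cc(OC)c(OC)c(OC)c2)c(O)c1` differs from compound 1 by methoxy in place of hydrogen on an aromatic carbon. Within the data shown here, no step between measured compounds is available to calibrate this change. A move toward a lower number in this assay is expected, since compound 3 is estimated to sit at 2500 nM, between 600 nM and 10000 nM. The expected change is a 3.4-fold lower number from compound 1 to compound 3 (0.53 log units; beyond the scatter).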

Compound 3, half-maximal inhibitory concentration: 5300 nM
The estimate for compound 3 lay 2.1-fold (0.33 log units) below the measured number; measured number inside the range.
By their numbers in this assay, from the lowest: compounds 2, 3 and 1 (each within the scatter of the next).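

Methoxy in place of hydrogen on this aromatic carbon, ortho to two methoxy groups and para to a large group, gives a 1.6-fold lower number from compound 1 to compound 3 (0.20 log units; within the scatter) in this assay, so compound 1 and compound 3 count as alike here. This one-place step shows that the position accepts a methoxy group with no change beyond the scatter. No supporting evidence bears on why this is so. As far as these compounds go, whether an amine, a carboxylic acid or a longer chain such as butoxy at this position would behave alike stays open. So does whether methoxy would give a similar step on another core.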